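The compounds below may be only part of what the source reports. "The series", "measured", "known", "first", "only" and "open" are said of these compounds alone.

For the measured compounds named here, compound 3 `CCCCCCCCCCCCCCC(CO)NC(=O)CCCC(=O)O` has, in an ADME assay on cells (Splenocyte, Mus musculus, strain BALB/c) for cytotoxicity, read by MTT assay, tested at 10 ug/mL (a lower number here means a weaker effect, a higher number a stronger effect of the compound at the concentration tested), the highest of the three numbers so far, with compound 3 giving 14.5%; its nearest neighbour is compound 1 `CCCCCCCCCCCCCCC(COCc1ccccc1)NCC`, which in this assay gives 11.9%, and the furthest is compound 2 `CCCCCCCCCCCCCCC(COCc1ccccc1)NC(=O)CCCC(=O)O`, which gives 6.4%, both gaps within the scatter. Compound 4 `CCCCCCCCCCCCCCC(CO)NCCCCCC` differs from compound 3 by hexyl in place of (3-carboxypropyl)carbonyl on an amine nitrogen. The measured steps that bear on it are a number 5.5 percentage points lower from compound 1 to compound 2 (within the scatter) and a number 8.1 percentage points higher from compound 2 to compound 3 (within the scatter), both within the scatter; the first runs in the opposite sense to the present exchange at the amine nitrogen, so at most a small rise is expected, as a number 3.5 percentage points higher from compound 3 to compound 4 (within the scatter). Compound 4 is therefore estimated at 18%, within 6% to 34%.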

Compound 4, a percentage reported as activity, at one concentration (the size of the read-out at that concentration, not a potency): 14.6%
Compound 4: middle estimate off by 3.4 percentage points, on the high side, within the range that was stated.
By their numbers in this assay, from the lowest: compounds 2, 1, 3 and 4 (each within the scatter of the next).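

With hydrogen on the oxygen, hexyl in place of (3-carboxypropyl)carbonyl on the amine nitrogen gives, in this assay, a number 0.1 percentage points higher from compound 3 to compound 4 (within the scatter). With benzyl on the oxygen, the exchange at this nitrogen gave a number 5.5 percentage points lower from compound 1 to compound 2 (within the scatter), so neither exchange there has yet separated from the scatter, even between a group with hydrogen-bond donors and acceptors and one with none. No measurement bears on why this position gives so small a step. Still open, going by these compounds, is whether a longer chain on this nitrogen, or an amine carried on that chain, would give a step beyond the scatter.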